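Predicting Lipophilicity After an Aryl Swap on the Sulfonamide

A few compounds are considered here, and "the series" means these few. Any claim that something is new, unique, unknown or untested is made for them only; others in the source may bear on it.

Compound 1 `CCc1ccc(N(CC(C)C)S(=O)(=O)c2ccc3c(c2)C(O)CC(C2CCOCC2)O3)cc1` is the starting point. In a physicochemical assay for lipophilicity, at pH 7.4 (a lower number here means a more polar compound, a higher number a more lipophilic compound), compound 1 gives 4.12. Compound 2 `CCc1ccc(N(CC(C)C)S(=O)(=O)c2ccc3c(c2)C(O)C[C@H](C2CCOCC2)O3)cc1` gives 4.12 in this assay, and the step of no change at the digits printed from compound 1 to compound 2 (within the scatter) is what one would expect given that (the fact that one of compounds 1 and 2 is drawn with a defined configuration and the other without, at the place where they differ). Compound 3 `CCc1ccc(N(CC(C)C)S(=O)(=O)c2ccc3c(c2)C(O)CC(CC2CCOCC2)O3)cc1` gives 4.44 in this assay, the step being a number 0.32 log units higher from compound 1 to compound 3 (beyond the scatter). Compound 1 is therefore level with compound 2, and the two together sit at the low end of the three numbers, with compound 3 above them beyond the scatter.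

The next compound, compound 4 `CC(C)CN(c1ccccc1C(F)(F)F)S(=O)(=O)c1ccc2c(c1)C(O)CC(C1CCOCC1)O2`, differs from compound 1 in one place: 2-(trifluoromethyl)phenyl in place of 4-ethylphenyl on a sulfonamide nitrogen. Neither measured step touches this part of the molecule. The step from compound 1 to compound 2 changes only how a stereocentre is drawn, and the step from compound 1 to compound 3 adds a single carbon to the group on a saturated ring carbon, giving a modest rise. Neither tells how an aromatic group of 8 heavy atoms being replaced by one of 10 heavy atoms, three of them fluorine, will shift the reading.

Going by the values given here, with no direct precedent, the expectation for compound 4 is a step of a number 0.03 log units higher from compound 1 to compound 4 (within the scatter) that stays within the scatter. Compound 4 is thus estimated at 4.15, with a range from 3.65 to 4.65.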

Compound 4, distribution coefficient: 4.14
For compound 4 the middle estimate is 0.01 log units above the measured one; low and high end bracket the measured number.
By their numbers in this assay, from the lowest: compounds 1, 2, 4 and 3 (each within the scatter of the next, the first and the last beyond it).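

At the sulfonamide nitrogen, 2-(trifluoromethyl)phenyl in place of 4-ethylphenyl gives, in this assay, a number 0.02 log units higher from compound 1 to compound 4 (within the scatter). Going by these compounds alone, the earlier steps touched only a drawn stereocentre and the group on a saturated ring carbon, so this is the first reading at this position: an aromatic group of 10 heavy atoms, 3 of them fluorine, can take the place of one of 8 carbon atoms while the two readings stay within the scatter of each other. Nothing available here accounts for how these two groups come to read alike.

This single pair swaps two things at once, removing an ethyl group and adding a trifluoromethyl group, so it cannot show whether each swap alone would leave the reading within the scatter or whether the two merely cancel, a question that a plain phenyl group on the same nitrogen would address. It also leaves open how far this tolerance extends, since a ring carrying an amine or a carboxylic acid, or a pyridine ring, could read quite differently on the core of compound 1.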